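Oxolan-3-yl in place of oxan-4-yl: outlook for compound 4

The compounds below may be only part of what the source reports. "The series", "measured", "known", "first", "only" and "open" are said of these compounds alone.

In a physicochemical assay for solubility, read by chemiluminescence (a higher number here means a more soluble compound, a lower number a less soluble compound), compound 1 (`Cn1ccc(C(=O)N(CC(=O)Nc2cc(F)cc(F)c2)C2CCCCC2)n1`) gives 163 ug/mL, compound 2 (`O=C(CN(C(=O)c1ccc(-c2ccccn2)cc1)C1CCCOC1)Nc1cc(F)cc(F)c1`) gives 56 ug/mL and compound 3 (`O=C(CN(C(=O)c1ccc(-c2ccccn2)cc1)C1CCOCC1)Nc1cc(F)cc(F)c1`) gives 99 ug/mL. Compound 3 lies within the scatter of both other compounds, so its number is not separated from either.

Compound 4 (`O=C(CN(C(=O)c1ccc(-c2ccccn2)cc1)C1CCOC1)Nc1cc(F)cc(F)c1`) follows from compound 3 by the change (oxolan-3-yl in place of oxan-4-yl on an amide-type nitrogen), with oxolan-3-yl in place of oxan-4-yl on an amide-type nitrogen.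

Going by the values given here, only one measured step bears on this place: a 1.8-fold higher number from compound 2 to compound 3 (0.25 log units; within the scatter), with oxan-4-yl in place of oxan-3-yl on the same nitrogen. That step stays within the scatter. Among the compounds with values here, compound 1 differs in more than one place and offers no matching step. Within the data shown here, no measured compound yet carries oxolan-3-yl, so the evidence is indirect.

The expected step is a 1.2-fold lower number from compound 3 to compound 4 (0.09 log units; within the scatter), with nothing expected beyond the scatter in either direction. For compound 4 the estimated value in this assay is 80 ug/mL, with an expected range of 42 ug/mL to 150 ug/mL.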

Compound 4, solubility: 102 ug/mL
The estimate for compound 4 lay 1.3-fold (0.11 log units) below the measured number; low and high end bracket the measured number.
By their numbers in this assay, from the lowest: compounds 2, 3, 4 and 1 (each within the scatter of the next, the first and the last beyond it).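

In this assay, the ring on the amide-type nitrogen now has a direct reading for oxolan-3-yl: a 1.0-fold higher number from compound 3 to compound 4 (0.01 log units; within the scatter) and a 1.8-fold higher number from compound 2 to compound 4 (0.26 log units; within the scatter) both stay within the scatter. This position therefore accepts a five-membered as well as a six-membered non-aromatic ring with one oxygen, and compounds 2, 3 and 4, carrying oxan-3-yl, oxan-4-yl and oxolan-3-yl, are not separated from one another in this read-out. Nothing available explains this result.

Still open, as far as these compounds go, is whether the same holds without the ring oxygen, as with cyclopentyl, or with an open-chain ether such as 2-methoxyethyl. A ring bearing an amine, such as piperidin-4-yl, or a carboxylic acid on this nitrogen substituent could also read differently here.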